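The source may hold more compounds than are shown below. What is called first, only, known or untested is meant among the compounds shown, and "the series" means these compounds.

Two compounds in this set carry a measurement in a functional assay on MCF7 cells (Homo sapiens) for antiproliferative activity, read by WST assay, with a stated time of 48 h; on this read-out higher numbers stand for weaker inhibition and lower numbers for stronger inhibition. Compound 1 `Clc1cccc(Nc2ncnc3ccc(NCc4ccc5c(c4)OCCCO5)cc23)c1` gives 4.28 ug/mL in this assay. Compound 2 `O=C(Nc1ccc2ncnc(Nc3cccc(Br)c3)c2c1)C1COc2ccccc2O1` reaches only the limit of this assay, > 100 ug/mL, so for compound 2 no number is known, only that limit. Its position is the limit of > 100 ug/mL in this assay, at which 1 of the 2 values shown sits.

Compound 3 `O=C(Nc1ccc2ncnc(Nc3cccc(Cl)c3)c2c1)C1COc2ccccc2O1` is the next compound to be tested. It differs from compound 2 in one place: chloro in place of bromo on an aromatic carbon. Within the data shown here, no step between two measured compounds is available for this change, so the expectation for compound 3 rests on the limit of compound 2 alone, with compound 1 offering no comparable pair.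

The swap is expected to move the value little, and the expected step is a number no higher from compound 2 to compound 3 (the limit leaves the size open), not beyond the scatter of repeated measurements. Compound 3 is therefore expected to give about 100 ug/mL in this assay, between 30 ug/mL and 300 ug/mL, with a real chance that this assay again reports only a limit and no number.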

Compound 3, half-maximal inhibitory concentration: 52.2 ug/mL
Beside the measured number, compound 3's estimate is 1.9-fold (0.28 log units) above it; measured number inside the range.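

In this assay, chloro in place of bromo on the aromatic carbon yields a number where there was none before, as compound 3 gives 52.2 ug/mL. Compound 2 reaches only a limit of the assay, > 100 ug/mL. The change therefore reads as an at least 1.9-fold lower number from compound 2 to compound 3 (0.28 log units; that floor lies within the scatter), and how far the true step runs past that floor cannot be read because compound 2 stands at a limit: the limit of > 100 ug/mL in this assay, at which 1 of the 3 values shown sits.

On these data alone, whether fluoro, methyl or methoxy in the place of chloro on this aromatic carbon would shift the number remains open, as does the result of moving chloro to another carbon of that ring. Compound 1 differs from compound 2 and from compound 3 in more than one place, which leaves the part played by the amide link and by the group at its far end unresolved, and an amine or a carboxylic acid on that side remains an open question.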